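Trifluoromethyl to tert-butyl: what to expect for compound 4

This account rests on a few compounds, and the source may have more. Where it says the series, first, only, none or still open, it means among the compounds named here.

Measured so far, all in a functional assay for antagonist activity at transient receptor potential cation channel subfamily V member 1 (Homo sapiens), read by calcium flux; on this read-out higher numbers stand for weaker inhibition and lower numbers for stronger inhibition:
compound 1 `O=C(Nc1cccc2[nH]ncc12)N[C@@H]1CCOc2cc(C(F)(F)F)ccc21` — 4 nM
compound 2 `O=C(Nc1cccc2[nH]ncc12)N[C@H]1CCOc2cc(C(F)(F)F)ccc21` — 43 nM
compound 3 `O=C(Nc1cccc2[nH]ncc12)NC1CCOc2cc(OC(F)(F)F)ccc21` — 8 nM

Compound 1 gives the lowest of the three numbers; compound 3 sits within the usual scatter of it, while compound 2 stands clearly apart: an 11-fold higher number from compound 1 to compound 2 (1.03 log units; beyond the scatter), a step that rests on (the fact that compounds 1 and 2 differ only in the configuration as drawn). Compound 4 `CC(C)(C)c1ccc2c(c1)OCC[C@H]2NC(=O)Nc1cccc2[nH]ncc12` differs from compound 1 in one place: tert-butyl in place of trifluoromethyl on an aromatic carbon. None of the measured steps involves such an exchange, so this change has no precedent among these compounds; the only measured step concerns configuration alone. With nothing pointing either way, compound 4 is expected to give a number close to that of its parent. The expected step is a 2.0-fold higher number from compound 1 to compound 4 (0.30 log units; within the scatter), not beyond the scatter. The estimate for compound 4 is 8 nM, within a range from 2 nM to 40 nM.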

Compound 4, half-maximal inhibitory concentration: 31 nM
Estimate against measurement, compound 4: 3.9-fold (0.59 log units) below, and the stated range covers the measured number.
By their numbers in this assay, from the lowest: compounds 1 and 3 (each within the scatter of the next); then compounds 4 and 2 (each within the scatter of the next).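

In this assay this aromatic carbon proves sensitive to the group it carries: tert-butyl in place of trifluoromethyl gives a 7.8-fold higher number from compound 1 to compound 4 (0.89 log units; beyond the scatter) even though the two groups hold the same count of heavy atoms. Inhibition is weakened but not lost, since compound 4 still gives 31 nM in this assay. The evidence at hand says nothing about why this exchange has the effect it has.

Still open, on these data alone, is how smaller or different groups would read at this carbon, such as methyl, chlorine, an amine or a carboxylic acid.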